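The source may report more compounds than this note shows. Statements on the series, on what has been measured and on what is new or still open speak of the compounds shown alone.

Measured so far in a functional assay on MKN-45 cells (Homo sapiens) for cytotoxicity, read by MTT assay, with a stated time of 72 h; a higher number here means a weaker inhibitor, a lower number a stronger inhibitor:

compound 1, `CN(C)CCn1cnnc1-c1cc(Oc2ccc(NC(=O)N/N=C/c3cccc(Br)c3)cc2F)ccn1`, 450 nM
compound 2, `CN(C)CCn1cnnc1-c1cc(Oc2ccc(NC(=O)N/N=C/c3ccc(O)cc3)cc2F)ccn1`, 820 nM
compound 3, `CN(C)CCn1cnnc1-c1cc(Oc2ccc(NC(=O)N/N=C/c3ccccc3O[N+](=O)[O-])cc2F)ccn1`, 1020 nM

Compound 3 carries the highest number of the three. Against compound 2 the gap is a 1.2-fold higher number from compound 2 to compound 3 (0.09 log units; within the scatter), so the two cannot be ordered; against compound 1 it is a 2.3-fold higher number from compound 1 to compound 3 (0.36 log units; beyond the scatter), a modest separation. The three compounds share the same core and differ only in the aryl group on the carbon with a double bond to nitrogen, and the whole spread across them is small.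

Compound 4 is `COc1ccc(/C=N/NC(=O)Nc2ccc(Oc3ccnc(-c4nncn4CCN(C)C)c3)c(F)c2)c(OC)c1OC`, not yet measured in this assay. Relative to compound 3 the change is 2,3,4-trimethoxyphenyl in place of 2-(nitrooxy)phenyl on a carbon with a double bond to nitrogen. Among the compounds with values here, every step so far bears on this position: a 1.8-fold higher number from compound 1 to compound 2 (0.26 log units; within the scatter) and a 1.2-fold higher number from compound 2 to compound 3 (0.09 log units; within the scatter) stay within the scatter, and a 2.3-fold higher number from compound 1 to compound 3 (0.36 log units; beyond the scatter) only just passes it. Three different aryl groups have moved the number little, so a fourth is expected to do the same; no step beyond the scatter is expected, with a slight lean toward a lower number given that compound 3 already sits at the top of the range. The estimated step for compound 4 is a 1.2-fold lower number from compound 3 to compound 4 (0.08 log units; within the scatter), and compound 4 is expected to give 850 nM, within 400 nM to 1900 nM.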

Compound 4, half-maximal inhibitory concentration: 2020 nM
For compound 4 the middle estimate is 2.4-fold (0.38 log units) below the measured one; the measured number lies above the stated range.
By their numbers in this assay, from the lowest: compounds 1, 2, 3 and 4 (each within the scatter of the next, the first and the last beyond it).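

In this assay, within the data shown here, the position on a carbon with a double bond to nitrogen now gives a wider spread than the first three aryl groups did: 2,3,4-trimethoxyphenyl in place of 3-bromophenyl gives a 4.5-fold higher number from compound 1 to compound 4 (0.65 log units; beyond the scatter) as the largest step so far, and in place of 4-hydroxyphenyl it gives a 2.5-fold higher number from compound 2 to compound 4 (0.39 log units; beyond the scatter) as a second step that passes the scatter. Against 2-(nitrooxy)phenyl the same group gives a 2.0-fold higher number from compound 3 to compound 4 (0.30 log units; within the scatter) and stays within the scatter, so compound 3 and compound 4 cannot be ordered, and the position tolerates aryl exchange without being wholly indifferent to it, with modest steps only. No measurement on hand bears on the reason for these steps.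

The compounds shown leave open whether the steps follow from the number of methoxy groups, since a phenyl carrying a single methoxy group would separate one from three. They also leave open how this position responds to groups outside the aryl types seen here, such as a carboxylic acid, an amine on the phenyl ring, or a saturated cyclohexyl ring.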